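This account rests on a few compounds, and the source may have more. Where it says the series, first, only, none or still open, it means among the compounds named here.

Working notes on the phenoxy-chain series.

Compound 3 `Cc1cc(C)c(NC(=O)C(C)(C)CCCCCCOc2ccc(Cl)cc2)c2c1CC(C)(C)O2` gives 76 nM in an assay for inhibition of acyl-CoA:cholesterol acyltransferase (Oryctolagus cuniculus), using microsomes; on this read-out higher numbers stand for weaker inhibition and lower numbers for stronger inhibition. Among the numbers reported, compound 3 stands lowest of two, with compound 2 `Cc1cc(C)c(NC(=O)C(C)(C)CCCCCOc2ccccc2)c2c1CC(C)(C)O2` nearest at 86 nM, and the two sit within the scatter of each other. The remaining member, compound 1 `Cc1cc(C)c(NC(=O)C(C)(C)CCCCCCN2CCCCC2)c2c1CC(C)(C)O2`, is reported only as a limit of the assay, > 500 nM, so it is not a number. The step of a 1.1-fold lower number from compound 2 to compound 3 (0.05 log units; within the scatter) is within the scatter; the steps of an at least 5.8-fold lower number from compound 1 to compound 2 (0.76 log units; beyond the scatter) and an at least 6.5-fold lower number from compound 1 to compound 3 (0.81 log units; beyond the scatter) are both beyond it, but each runs from a limit of > 500 nM in this assay, at which 1 of the 3 values shown sits, and says nothing about the aromatic ring itself.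

Compound 4 `Cc1ccc(OCCCCCCC(C)(C)C(=O)Nc2c(C)cc(C)c3c2OC(C)(C)C3)cc1` differs from compound 3 by methyl in place of chloro on an aromatic carbon. For the measured compounds named here, no measured step exchanges one group on that aromatic ring for another; the only step touching the ring, compound 2 to compound 3, was within the scatter. Nothing in the series therefore gives grounds to expect a step beyond the scatter in this assay, in either direction. The working expectation for compound 4 is 80 nM, estimated to fall between 35 nM and 180 nM, which means an expected step of a 1.1-fold higher number from compound 3 to compound 4 (0.02 log units; within the scatter).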

Compound 4, half-maximal inhibitory concentration: 50 nM
Beside the measured number, compound 4's estimate is 1.6-fold (0.20 log units) above it; the measured number falls inside the stated range.
By their numbers in this assay, from the lowest: compounds 4, 3 and 2 (each within the scatter of the next). At a limit, above all of these: compound 1.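

Replacing chloro with methyl on an aromatic carbon, para to a large group, gives the series its first measured exchange of one group for another on this ring, and in this assay the change stays within the scatter (a 1.5-fold lower number from compound 3 to compound 4 (0.18 log units; within the scatter)). Read against the unsubstituted phenoxy chain, the (4-methylphenoxy)methyl group also stays within the scatter (a 1.7-fold lower number from compound 2 to compound 4 (0.24 log units; within the scatter)), so on these compounds neither chloro nor methyl separates from the other at this place, and neither chain separates from the phenoxy chain of compound 2. The step from the piperidin-1-yl chain (an at least 10-fold lower number from compound 1 to compound 4 (1.00 log units; beyond the scatter)) starts from compound 1, whose entry is a limit of the assay and not a number: the limit of > 500 nM in this assay, at which 1 of the 4 values shown sits.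

From the compounds shown here alone, whether this ring position responds to anything other than chloro and methyl stays open, for example a methoxy group, a carboxylic acid or an amine in the same place. Also open, going by these compounds, is what a longer chain would do with the ring held constant, since the step from compound 2 changes chain length and ring substituent together.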